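This account rests on a few compounds, and the source may have more. Where it says the series, first, only, none or still open, it means among the compounds named here.

Measured in a functional assay on K562 cells (Homo sapiens) for cytotoxicity, read by ELISA, with a stated time of 4 days; on this read-out lower numbers stand for stronger inhibition and higher numbers for weaker inhibition:
compound 1 (`Cc1ccccc1-c1cc(-c2ccoc2)cc(-c2ccc(Cl)s2)n1`) gives 12300 nM
compound 2 (`Cc1cccc(-c2cc(-c3ccoc3)cc(-c3ccc(Cl)s3)n2)c1`) gives 13700 nM

Compound 2 stands level with compound 1, within the scatter of repeated measurements. Compound 3 (`Clc1ccc(-c2cc(-c3ccoc3)cc(-c3ccccc3Cl)n2)s1`) carries 2-chlorophenyl in place of 3-methylphenyl on an aromatic carbon. For the measured compounds named here, the only measured step also exchanges a group on that aromatic carbon, and it stayed small (a 1.1-fold higher number from compound 1 to compound 2 (0.05 log units; within the scatter)). Going by the values given here, no compound with 2-chlorophenyl has been measured, so this is thin guidance, and no step beyond the scatter is expected in this assay. The estimate is therefore a small move in either direction (a 1.1-fold lower number from compound 2 to compound 3 (0.06 log units; within the scatter)). Compound 3 is expected at 12000 nM (estimated range 5000 nM to 30000 nM).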

Compound 3, half-maximal inhibitory concentration: 15800 nM
Compound 3: middle estimate off by 1.3-fold (0.12 log units), on the low side; low and high end bracket the measured number.
By their numbers in this assay, from the lowest: compounds 1, 2 and 3 (each within the scatter of the next).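

On the aromatic carbon next to the ring nitrogen, 2-chlorophenyl replaces 3-methylphenyl in this assay with only a small step (a 1.2-fold higher number from compound 2 to compound 3 (0.06 log units; within the scatter)). Chloro in place of methyl on the phenyl ring also gives a small step (a 1.3-fold higher number from compound 1 to compound 3 (0.11 log units; within the scatter)), so a chloro-bearing phenyl ring stays within the scatter of both methyl-bearing ones. No available evidence explains this result. From the compounds shown here alone, what remains open is whether an amine or a carboxylic acid on this phenyl ring, or a group other than phenyl at this position, would shift the number beyond the scatter.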